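The source may hold more compounds than are shown below. What is called first, only, known or untested is meant among the compounds shown, and "the series" means these compounds.

The series concerns benzoylated sugar glycosides examined in an ADME assay on Bel-7402 cells (Homo sapiens) for cytotoxicity; a higher number here means a weaker inhibitor, a lower number a stronger inhibitor. Compound 1 `O=C(OC[C@H]1O[C@@H](OC[C@H](O)[C@@H](O)c2ccc(O)cc2)[C@H](O)[C@@H](O)[C@@H]1O)c1ccccc1` gives > 10000 nM, which is a limit of the assay rather than a number. Compound 2 `O=C(OC[C@H]1O[C@@H](OC[C@H]2O[C@@H](OCc3ccccc3)[C@H](O)[C@@H](O)[C@@H]2O)[C@H](O)[C@@H](O)[C@@H]1O)c1ccccc1` gives > 10000 nM in this assay, again a limit and not a measured value. Among the compounds with values here, compound 2 thus stands at the edge of what this assay can report, and the one other value shown sits at that same edge (the limit of > 10000 nM in this assay, at which 2 of the 2 values shown sit). Within the data shown here, no step between two measured compounds is available, so no size of change has yet been observed.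

Compound 3 `O=C(OC[C@H]1O[C@@H](OC[C@H]2O[C@@H](OC(=O)c3ccccc3)[C@H](O)[C@@H](O)[C@@H]2O)[C@H](O)[C@@H](O)[C@@H]1O)c1ccccc1` differs from compound 2 in a single place: benzoyl in place of benzyl on an oxygen on a saturated carbon. Benzyl leaves and benzoyl enters on an oxygen on a saturated carbon whose other neighbours are a saturated ring carbon; cut one bond further out, the change reads benzyloxy to benzoyloxy.

Because both values shown rest at the limit (the limit of > 10000 nM in this assay, at which 2 of the 2 values shown sit), the step is expected to be none beyond the scatter: a step that the limit leaves unreadable from compound 2 to compound 3. Compound 3 is therefore estimated at 20000 nM, with a range from 8000 nM to 60000 nM, and is expected most likely to be reported again only as a limit.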

Compound 3, half-maximal inhibitory concentration: > 10000 nM
Compound 3: no number, only a limit; the forecaster's own chance of this, stated with the estimate: 85%; the middle value does not contradict the limit.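

In this assay compound 3 gives > 10000 nM, again a limit and not a number. No size can therefore be read for the change from compound 2 to compound 3, because both results are limits: the limit of > 10000 nM in this assay, at which 3 of the 3 values shown sit.

The compounds shown leave open how far past that limit each one lies in this assay, and whether benzoyl and benzyl differ at all.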